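Four Configurational Isomers in One Cell Inhibition Assay

A few compounds are considered here, and "the series" means these few. Any claim that something is new, unique, unknown or untested is made for them only; others in the source may bear on it.

Compound 1, `CCOC(=O)/C=C/NC(=O)[C@H](O)C(C)(C)CO`, in an ADME assay on HEK293 cells (Homo sapiens) for inhibition, read by CellTiter-Glo, with a stated time of 96 h, tested at 100 uM; a lower number here means less inhibition, a higher number more inhibition at the concentration tested (going by the name of the read-out): -5%
Compound 2, `CC(C)(CO)[C@H](O)C(=O)N/C=C/C(=O)OCc1ccccc1`, in this assay: -6%
Compound 3, `CC(C)(CO)[C@H](O)C(=O)N/C=C\C(=O)OCc1ccccc1`, in this assay: -7%

All three numbers in this assay sit together within the scatter, so compound 3 is not set apart from compound 1 or compound 2. For the measured compounds named here, the one measured step with the same atoms, a number 1 percentage points lower from compound 2 to compound 3 (within the scatter), is within the scatter, which fits (the fact that compounds 2 and 3 differ only in the configuration as drawn). Compound 4, `CC(C)(CO)[C@@H](O)C(=O)N/C=C/C(=O)OCc1ccccc1`, is not yet measured. From compound 3 it changes as follows: the two compounds have the same atoms and bonds and differ only in configuration as drawn: 2 of 2 stereo elements differ; a stereocentre at a saturated chain carbon is drawn S in compound 3 and R in compound 4; a double bond is drawn Z in compound 3 and E in compound 4. The double-bond change has a measured precedent that gave no step beyond the scatter; the inversion of the stereocentre has none among the measured compounds. The expected step is therefore a number 1 percentage points higher from compound 3 to compound 4 (within the scatter), no change beyond the scatter. Compound 4 is estimated at -6%, between -16% and 4%.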

Compound 4, a percentage reported as inhibition, at one concentration (the size of the read-out at that concentration, not a potency): 5%
Beside the measured number, compound 4's estimate is 11 percentage points below it; measured number outside the range, above it.
By their numbers in this assay, from the lowest: compounds 3, 2, 1 and 4 (each within the scatter of the next, the first and the last beyond it).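

In this assay, inverting the stereocentre at a saturated chain carbon while the double bond stays E gives a number 11 percentage points higher from compound 2 to compound 4 (beyond the scatter), a shift that rests on configuration alone: the fact that compounds 2 and 4 differ only in the configuration as drawn. The step in which the double bond changes as well, a number 12 percentage points higher from compound 3 to compound 4 (beyond the scatter), carries the same inversion, so this carbon is the one position here where configuration has a printed step beyond the scatter. With phenyl in place of methyl, a number 10 percentage points higher from compound 1 to compound 4 (within the scatter) gives no such separation.

The compounds shown leave open whether the inversion has the same effect with the double bond drawn Z or in the core of compound 1. They also leave open how an amine in place of the hydroxyl on this carbon would read.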